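From One Ester to Another at the Assay Limit

A few compounds are considered here, and "the series" means these few. Any claim that something is new, unique, unknown or untested is made for them only; others in the source may bear on it.

In a functional assay on MCF7 cells (Homo sapiens), read by MTT assay, with a stated time of 48 h (on this read-out higher numbers stand for weaker inhibition and lower numbers for stronger inhibition), compound 1 `CCn1c(C(=O)NCCCN(C)C)ccc1C(CC)(CC)c1ccc(OCC(O)C(C)(C)C)c(C)c1` gives 490 nM. Compound 2 `CCn1c(C(=O)N(C)CCC#N)ccc1C(CC)(CC)c1ccc(OCC(O)C(C)(C)C)c(C)c1` gives only a limit of the assay, > 50000 nM. Compound 3 `C#CC(C)OC(=O)c1ccc(C(CC)(CC)c2ccc(OCC(O)C(C)(C)C)c(C)c2)n1CC` also gives only a limit, > 50000 nM, so no exact number is known for it.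

Compound 4 `CCn1c(C(=O)OCc2ccc(F)cc2)ccc1C(CC)(CC)c1ccc(OCC(O)C(C)(C)C)c(C)c1` differs from compound 3 in one group: 4-fluorobenzyl in place of 1-methylprop-2-yn-1-yl on an oxygen next to a carbonyl group. In words, 4-fluorobenzyl stands in place of 1-methylprop-2-yn-1-yl on an oxygen next to a carbonyl group.

Going by the values given here, no measured step makes this exact swap, but two bear on it. Replacing the (3-(dimethylamino)propyl)amino group of compound 1 gave large changes: an at least 100-fold higher number from compound 1 to compound 2 (2.00 log units; beyond the scatter), and an at least 100-fold higher number from compound 1 to compound 3 (2.00 log units; beyond the scatter). Compound 4 lacks that group too, so it is expected to stay near the limit, and the assay may again report only a limit. In this assay, the expected result is a number no higher from compound 3 to compound 4 (the limit leaves the size open), with no change beyond the scatter in either direction. For compound 4, the estimated value is 50000 nM, with an expected range of 15000 nM to 100000 nM.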

Compound 4, half-maximal inhibitory concentration: > 50000 nM
Compound 4 gave a limit, no number (the forecaster's own chance of this, stated with the estimate: 70%); the middle value lies on the limit itself.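

In this assay, the group on the oxygen next to the carbonyl group can change from the ringless 1-methylprop-2-yn-1-yl to 4-fluorobenzyl, which carries a six-membered aromatic ring, and compound 4 still gives only a limit of the assay, not a number. The steps from compound 3 to compound 4 and from compound 2 to compound 4 cannot be read, as each has a limit at both ends. The one readable step is an at least 100-fold higher number from compound 1 to compound 4 (2.00 log units; beyond the scatter), which makes this a third replacement of the (3-(dimethylamino)propyl)amino group that ends at the same limit: the limit of > 50000 nM in this assay, at which 3 of the 4 values shown sit.

As far as these compounds go, how compound 2, compound 3 and compound 4 rank against one another stays unknown. Also open, from the compounds shown here alone, is what a (2-(dimethylamino)ethyl)amino group, with a shorter chain, or a (3-aminopropyl)amino group on the carbonyl carbon would give.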